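From Acetamido to Cyclopentylcarbamoylamino in Compound 4

The source may report more compounds than this note shows. Statements on the series, on what has been measured and on what is new or still open speak of the compounds shown alone.

Compound 1 `O=C(Nc1ccc(-c2noc(-c3cccc(NS(=O)(=O)c4cccc(Cl)c4)c3)n2)c(Cl)c1)c1cccnc1` — > 10000 nM
Compound 2 `NS(=O)(=O)c1ccc(S(=O)(=O)Nc2cccc(-c3nc(-c4ccc(NC(=O)c5cccnc5)cc4Cl)no3)c2)cc1` — > 10000 nM
Compound 3 `CC(=O)Nc1ccc(S(=O)(=O)Nc2cccc(-c3nc(-c4ccc(NC(=O)c5cccnc5)cc4Cl)no3)c2)cc1` — 2500 nM

In a functional assay on MDA-MB-231 cells (Homo sapiens) for antiproliferative activity, read by MTT assay, with a stated time of 72 h (on this read-out lower numbers stand for stronger inhibition and higher numbers for weaker inhibition), compound 1 gives only a limit, > 10000 nM. Compound 2 likewise gives only a limit, > 10000 nM. Among the measured compounds shown here, compound 3 gives the sole actual number, 2500 nM, and so stands alone as the one compound with a measured value. The two steps that lead to it, an at least 4.0-fold lower number from compound 1 to compound 3 (0.60 log units; beyond the scatter) and an at least 4.0-fold lower number from compound 2 to compound 3 (0.60 log units; beyond the scatter), both replace the group on the sulfonyl sulfur and both sit against the shared limit (the limit of > 10000 nM in this assay, at which 2 of the 3 values shown sit).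

Compound 4 `O=C(Nc1ccc(S(=O)(=O)Nc2cccc(-c3nc(-c4ccc(NC(=O)c5cccnc5)cc4Cl)no3)c2)cc1)NC1CCCC1` keeps everything of compound 3 except the change (cyclopentylamino in place of methyl on a carbonyl carbon). For the measured compounds named here, none of the measured steps touches this carbonyl carbon; each concerns the sulfonyl sulfur or an aromatic carbon, so none reads directly onto the present change. Without a bearing step, the expectation for compound 4 is a step of no change at the digits printed from compound 3 to compound 4 (within the scatter), within the scatter. Compound 4 is therefore estimated at 2500 nM, in a range from 800 nM to 8000 nM.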

Compound 4, half-maximal inhibitory concentration: > 10000 nM
Compound 4: only a limit was reported (the forecaster's own chance of this, stated with the estimate: 20%); at least 4.0-fold (0.60 log units) between middle value and limit.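

In this assay, the carbonyl carbon of the acetamido group responds to change: cyclopentylamino in place of methyl gives an at least 4.0-fold higher number from compound 3 to compound 4 (0.60 log units; beyond the scatter). The earlier steps concerned only the sulfonyl sulfur or an aromatic carbon, so this is the first reading at this carbonyl carbon, and it leaves compound 3 as the only compound shown with an actual number. The step from compound 2 to compound 4 cannot be read, and the full size of the step to compound 4 stays unknown, as the value of compound 4 is a limit: the limit of > 10000 nM in this assay, at which 3 of the 4 values shown sit.

As far as these compounds go, it remains open whether the cyclopentyl ring or the nitrogen that enters with it goes with the higher number, and methylamino or cyclopentyl on this carbonyl carbon would separate the two. From the compounds shown here alone, compound 3 gives 2500 nM, and whether any group at this position, such as ethyl or methoxy, gives a still lower number is also open.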